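Two Chlorines Added to a Benzyl Ether

The source may report more compounds than this note shows. Statements on the series, on what has been measured and on what is new or still open speak of the compounds shown alone.

Measured so far:
compound 1 `C=CCc1ccc(OCc2ccccc2)c(-c2ccc(O)c(CC=C)c2)c1` — 22300 nM
compound 2 `C=CCc1ccc(OCc2c(Cl)cccc2Cl)c(-c2ccc(OCc3c(Cl)cccc3Cl)c(CC=C)c2)c1` — > 50000 nM
compound 3 `C=CCc1ccc(OCc2ccccc2)c(-c2ccc(OCc3ccccc3)c(CC=C)c2)c1` — > 50000 nM

Of the compounds shown here, three have been tested in a functional assay on MCF7 cells (Homo sapiens) for inhibition, read by MTT assay, with a stated time of 72 h; a lower number here means a stronger inhibitor, a higher number a weaker inhibitor. Going by the values given here, compound 1 gives 22300 nM, the only value in this set that is a number. For compound 2 the result is a limit of the assay, > 50000 nM. For compound 3 the result is likewise a limit, > 50000 nM. Compound 1 therefore stands alone as a measured number, the other two resting at the limit of > 50000 nM in this assay, at which 2 of the 3 values shown sit.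

Among the compounds with values here, the one step that can be sized is an at least 2.2-fold higher number from compound 1 to compound 3 (0.35 log units; beyond the scatter), benzyl in place of hydrogen on an oxygen on an aromatic ring. Compound 4 `C=CCc1ccc(OCc2ccc(Cl)cc2Cl)c(-c2ccc(O)c(CC=C)c2)c1` differs from compound 1 in a different place: 2,4-dichlorophenyl in place of phenyl on a saturated chain carbon bound to an oxygen on an aromatic ring. Within the data shown here, no measured step follows chlorine on the benzyl group by itself; compounds 2 and 3 both carry benzyl groups on both oxygens and both sit at the limit, so they show no separation from one another. Among the measured compounds shown here, compound 4 keeps the hydrogen on an oxygen on an aromatic ring that compound 1 has, and the one sized step concerns that hydrogen rather than the benzyl ring. The expected step for compound 4 is a 1.1-fold higher number from compound 1 to compound 4 (0.05 log units; within the scatter). Compound 4 is accordingly estimated at 25000 nM, in the range 10000 nM to 50000 nM.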

Compound 4, half-maximal inhibitory concentration: 27400 nM
Compound 4: middle estimate off by 1.1-fold (0.04 log units), on the low side; low and high end bracket the measured number.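

In this assay, the change from benzyl to 2,4-dichlorobenzyl, on a saturated chain carbon bound to an oxygen on an aromatic ring, gives a 1.2-fold higher number from compound 1 to compound 4 (0.09 log units; within the scatter), so compound 1 and compound 4 cannot be told apart. Going by these compounds alone, this is the first reading of a change on the benzyl ring itself, as the one step sized earlier concerned the hydrogen on the other oxygen, and compound 2 and compound 3 offer no comparison of their benzyl groups, both resting at a limit of the assay: the limit of > 50000 nM in this assay, at which 2 of the 4 values shown sit. With that hydrogen kept, the pair of compound 1 and compound 4 shows that 2,4-dichlorophenyl can stand in place of phenyl at this position with no step beyond the scatter, though this rests on one pair alone.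

The compounds shown leave open whether a different group on the benzyl ring, such as an amine or a carboxylic acid, would give a step beyond the scatter in this assay. They also leave open what a longer chain in place of the benzyl group would do on the core of compound 1.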